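This account rests on a few compounds, and the source may have more. Where it says the series, first, only, none or still open, it means among the compounds named here.

Series of ester-linked triazole derivatives on a shared terpenoid core, tested in a functional assay on DU-145 cells (Homo sapiens) for antiproliferative activity, read by MTT assay, with a stated time of 48 h; on this read-out higher numbers stand for weaker inhibition and lower numbers for stronger inhibition.

Compound 1 `COc1ccc(-n2cc(COC(=O)/C(C)=C/CC/C(C)=C/CC/C(C)=C/CC[C@@H]3[C@@]4(C)CCC(=O)C(C)(C)[C@H]4CC[C@@]3(C)O)nn2)cc1` gives 135000 nM in this assay. Compound 3 `C/C(=C\CC/C(C)=C/CC[C@@H]1[C@@]2(C)CCC(=O)C(C)(C)[C@H]2CC[C@@]1(C)O)CC/C=C(\C)C(=O)OCc1cn([C@@H]2C[C@@H](n3cc(C)c(=O)[nH]c3=O)O[C@H]2CO)nn1` gives 13800 nM. Compound 2 `C/C(=C\CC/C(C)=C/CC[C@@H]1[C@@]2(C)CCC(=O)C(C)(C)[C@H]2CC[C@@]1(C)O)CC/C=C(\C)C(=O)OCc1cn(C[C@@H]2O[C@H](n3ccc(=O)[nH]c3=O)[C@H]3OC(C)(C)O[C@H]32)nn1` returns only a limit in this assay, > 150000 nM; this is the limit of > 150000 nM in this assay, at which 1 of the 3 values shown sits. Among the two numbers shown, compound 1 stands highest, with compound 3 nearest at a lower number that lies beyond the scatter.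

Compound 4 `C/C(=C\CC/C(C)=C/CC[C@@H]1[C@@]2(C)CCC(=O)C(C)(C)[C@H]2CC[C@@]1(C)O)CC/C=C(\C)C(=O)OCc1cn(-c2cccc(C(F)(F)F)c2)nn1` is not yet measured. It differs from compound 1 by 3-(trifluoromethyl)phenyl in place of 4-methoxyphenyl on an aromatic nitrogen. Within the data shown here, no step between measured compounds bears on an exchange of this kind, and the two aryl groups on the ring nitrogen are the only difference between compound 1 and compound 4.

The step from compound 1 to compound 4 is expected to be small, a 1.4-fold lower number from compound 1 to compound 4 (0.13 log units; within the scatter), with no direction that can be supported beyond the scatter. Compound 4 is therefore estimated at 100000 nM in this assay, within a range from 30000 nM to 200000 nM.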

Compound 4, half-maximal inhibitory concentration: > 150000 nM
Compound 4: a limit, no number; the forecaster's own chance of this, stated with the estimate: 25%; middle value at least 1.5-fold (0.17 log units) from the limit.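

In this assay compound 4 returns only a limit, > 150000 nM, and not a number. Among these compounds, exchanging 4-methoxyphenyl for 3-(trifluoromethyl)phenyl on the aromatic nitrogen gives the first single-place step, an at least 1.1-fold higher number from compound 1 to compound 4 (0.04 log units; that floor lies within the scatter); this is a floor only, so the true size of the step stays unknown, and no stronger inhibition appears. The limit now holds a second compound, so differences at this end of the read-out can no longer be resolved: the limit of > 150000 nM in this assay, at which 2 of the 4 values shown sit.

Going by these compounds, whether an unsubstituted phenyl, or a phenyl bearing an amine or a carboxylic acid, on the ring nitrogen would bring a value back into the readable range remains open. Also open, on these data alone, is which feature of the group on the ring nitrogen of compound 3 goes with its 13800 nM.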